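Vero Cell Cytotoxicity: From Compound 3 to Compound 4

This account rests on a few compounds, and the source may have more. Where it says the series, first, only, none or still open, it means among the compounds named here.

Compound 1 `O=C(c1ccncc1)N1N=C(c2cc3ccccc3o2)CC1c1ccccc1Cl` — a limit of > 210000 nM in an ADME assay on Vero cells (Chlorocebus sabaeus) for cytotoxicity, read by MTT assay, with a stated time of 72 h; on this read-out higher numbers stand for weaker inhibition and lower numbers for stronger inhibition.
Compound 2 `COc1ccc(C2CC(c3cc4ccccc4o3)=NN2C(=O)c2ccncc2)cc1` — a limit of > 200000 nM in this assay.
Compound 3 `CCn1cc(C(=O)N2N=C(c3cc4ccccc4o3)CC2c2ccc(N(C)C)cc2)c(=O)c2ccc(C)nc21` — a limit of > 206000 nM in this assay.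

Compound 3 therefore stands only at a limit, and the two other values are limits as well (the limit of > 200000 nM in this assay, at which 1 of the 3 values shown sits, (the limit of > 206000 nM in this assay, at which 1 of the 3 values shown sits), (the limit of > 210000 nM in this assay, at which 1 of the 3 values shown sits)). For the measured compounds named here, the only measured step, a step that the two limits leave unreadable from compound 1 to compound 2, is left unreadable by its two limits. Compound 4 `CCn1cc(C(=O)N2N=C(c3cc4ccccc4o3)CC2c2ccco2)c(=O)c2ccc(C)nc21` differs from compound 3 as follows: furan-2-yl in place of 4-(dimethylamino)phenyl on a saturated ring carbon. Going by the values given here, no measured step bears readably on this change, so no step beyond the scatter is expected. Compound 4 is expected to give 210000 nM in this assay, with a range from 100000 nM to 400000 nM. The expected step that the limit leaves unreadable from compound 3 to compound 4 is estimated to be none beyond the scatter.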

Compound 4, half-maximal inhibitory concentration: > 185000 nM
Compound 4 ended at the assay's limit; the forecaster's own chance of this, stated with the estimate: 85%; the middle value does not contradict the limit.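

In this assay compound 4 gives > 185000 nM, which is a limit. For the compounds shown here, compound 3 also stands at a limit, and no step between compound 3 and compound 4 can be read. The compounds shown leave open whether furan-2-yl and 4-(dimethylamino)phenyl differ at all on this read-out.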